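Swapping fluoro for hydrogen on compound 3

The source may hold more compounds than are shown below. What is called first, only, known or untested is meant among the compounds shown, and "the series" means these compounds.

- compound 1 `Cc1cccc(NN=C2C(Cl)=C(Cl)C(Cl)=C2Cl)c1`: 2000 nM
- compound 2 `Fc1ccccc1NN=C1C(Cl)=C(Cl)C(Cl)=C1Cl`: > 3000 nM (a limit)
- compound 3 `Fc1cccc(NN=C2C(Cl)=C(Cl)C(Cl)=C2Cl)c1`: 500 nM

In a functional assay on RPMI-8226 cells (Homo sapiens) for cytotoxicity, read by MTT assay, with a stated time of 48 h (a lower number here means a stronger inhibitor, a higher number a weaker inhibitor), compound 3 gives 500 nM, the lower of the two exact numbers. For compound 2, > 3000 nM is a limit of the assay and not a number.

The next compound, compound 4 `ClC1=C(Cl)C(Cl)=C(Cl)C1=NNc1ccccc1`, differs from compound 3 as follows: hydrogen in place of fluoro on an aromatic carbon. This puts hydrogen in place of fluoro on an aromatic carbon, meta to a large group. Within the data shown here, the one measured step that bears on this is a 4.0-fold lower number from compound 1 to compound 3 (0.60 log units; beyond the scatter), a modest change with fluoro in place of methyl. Among the measured compounds shown here, no measured compound carries hydrogen there, so only a modest rise in the number is expected in this assay. The expected change is a 2.0-fold higher number from compound 3 to compound 4 (0.30 log units; within the scatter). Compound 4 is estimated at 1000 nM, with a range of 350 nM to 3000 nM.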

Compound 4, half-maximal inhibitory concentration: 600 nM
The estimate for compound 4 lay 1.7-fold (0.22 log units) above the measured number; the measured number falls inside the stated range.
By their numbers in this assay, from the lowest: compounds 3 and 4 (each within the scatter of the next); then compound 1. At a limit, above all of these: compound 2.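

At this aromatic carbon, meta to a large group, hydrogen in place of fluoro gives a 1.2-fold higher number from compound 3 to compound 4 (0.08 log units; within the scatter), so fluoro is not needed here for the low number. Hydrogen in place of methyl gives a 3.3-fold lower number from compound 1 to compound 4 (0.52 log units; beyond the scatter), which sets methyl apart from the other two groups at this carbon. A further step, an at least 5.0-fold lower number from compound 2 to compound 4 (0.69 log units; beyond the scatter), rests on a limit and not a number: the limit of > 3000 nM in this assay, at which 1 of the 4 values shown sits.

The compounds shown leave open how an amine or a carboxylic acid at this carbon would read, and whether either would keep the number as low.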